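Adding a Hydroxy Group to a Compound Without Measured Cytotoxicity

A few compounds are considered here, and "the series" means these few. Any claim that something is new, unique, unknown or untested is made for them only; others in the source may bear on it.

Measured compounds:
- Compound 1, `C=C(CCC=C(C)C)[C@H](O)Cc1c(O)cc(O)cc1CCc1ccccc1`: in a functional assay on NCI-H1299 cells (Homo sapiens) for cytotoxicity, read by MTT assay, with a stated time of 48 h (on this read-out higher numbers stand for weaker inhibition and lower numbers for stronger inhibition), compound 1 gives > 40000 nM, which is a limit of the assay rather than a number.
- Compound 2, `CC1=CCc2c(O)cc(CCc3ccccc3)cc2OC1`: in this assay compound 2 gives > 40000 nM, again a limit of the assay rather than a number.

Going by the values given here, compound 1 and compound 2 share a core but differ in more than one place, so no single step between them can be read. What the two values show is simply that neither compound reached a measurable half-maximal inhibitory concentration in this assay. Among the compounds with values here, compound 2 therefore stands at the limit, together with the one other value shown, as described by the limit of > 40000 nM in this assay, at which 2 of the 2 values shown sit.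

Compound 3, `CC1=CCc2c(O)cc(CCc3ccccc3O)cc2OC1`, differs from compound 2 by hydroxy in place of hydrogen on an aromatic carbon. This is a small change, and since compound 2 gives only a limit, the step from compound 2 to compound 3 in this assay is expected to be none beyond the scatter, as a number no higher from compound 2 to compound 3 (the limit leaves the size open) expresses. Compound 3 is therefore expected to give about 40000 nM, in a range from 10000 nM to 80000 nM.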

Compound 3, half-maximal inhibitory concentration: > 40000 nM
Compound 3: a limit, no number; the forecaster's own chance of this, stated with the estimate: 70%; the middle value lies on the limit itself.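

Going by these compounds alone, compound 2 and compound 3 both stand at a limit of the assay rather than at a number, so no step between them can be read. The compounds shown leave open whether hydroxy in place of hydrogen on an aromatic carbon changes cytotoxicity at all, and how the three compounds compare, since all rest on a single limit: the limit of > 40000 nM in this assay, at which 3 of the 3 values shown sit.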